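Working notes: fluorinated aryl exchange on the shared core

The source may hold more compounds than are shown below. What is called first, only, known or untested is meant among the compounds shown, and "the series" means these compounds.

compound 1: `Nc1scc(CN2CCN(c3ccc(Cl)cc3F)CC2)c1C(=O)c1ccc(Cl)cc1` — -9.4%
compound 2: `Nc1scc(CN2CCN(c3cc(F)cc(F)c3)CC2)c1C(=O)c1ccc(Cl)cc1` — -5%
compound 3: `Nc1scc(CN2CCN(c3c(F)cc(F)cc3F)CC2)c1C(=O)c1ccc(Cl)cc1` — not yet measured

In a functional assay on CHO cells with adenosine receptor A1 (Homo sapiens) as the target, read by cAMP accumulation and immunoassay, with a stated time of 6 min, tested at 0.1 uM (a higher number here means a weaker effect of the compound at the concentration tested, a lower number a stronger effect), compound 1 gives -9.4% and compound 2 gives -5%. Both numbers lie close to zero, so neither compound shows a clear effect at the concentration tested. Within the data shown here, compound 2 sits beside compound 1 on the two numbers so far; the only measured step is a number 4.4 percentage points higher from compound 1 to compound 2 (within the scatter).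

The next compound is compound 3, `Nc1scc(CN2CCN(c3c(F)cc(F)cc3F)CC2)c1C(=O)c1ccc(Cl)cc1`. Its change from compound 2 is 2,4,6-trifluorophenyl in place of 3,5-difluorophenyl on an amine nitrogen in a ring.

Among the measured compounds shown here, the single step in hand bears on it only loosely: a number 4.4 percentage points higher from compound 1 to compound 2 (within the scatter) also exchanges one fluorinated phenyl for another on the same ring nitrogen and stays within the scatter. For the measured compounds named here, no measured step involves the 2,4,6-trifluorophenyl itself. Going by the values given here, with both measured numbers near zero and the one known step flat, no movement beyond the scatter in this assay is expected from this exchange.

Compound 3 is expected to give -5% in this assay, within -22% to 12%. The expected step is no change at the digits printed from compound 2 to compound 3 (within the scatter).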

Compound 3, a percentage reported as activity, at one concentration (the size of the read-out at that concentration, not a potency): -3.9%
Estimate against measurement, compound 3: 1.1 percentage points below; low and high end bracket the measured number.
By their numbers in this assay, from the lowest: compounds 1, 2 and 3 (each within the scatter of the next).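

At the amine nitrogen in a ring, 2,4,6-trifluorophenyl in place of 3,5-difluorophenyl gives a number 1.1 percentage points higher from compound 2 to compound 3 (within the scatter) in this assay and extends the comparison beyond the earlier pair of aryl groups. Against the chlorine-bearing group, 2,4,6-trifluorophenyl in place of 4-chloro-2-fluorophenyl gives a number 5.5 percentage points higher from compound 1 to compound 3 (within the scatter) in this assay, so across these three compounds neither the exchange of aryl group nor the third fluorine separates the numbers at the concentration tested. No supporting measurement is available to account for this flat reading.

The compounds shown leave open whether a phenyl without halogen, a methoxyphenyl or a pyridine ring on this ring nitrogen would move the number beyond the scatter, since all three groups here are halogenated phenyl rings. Readings at one concentration also give no potency, and they leave open whether a carboxylic acid or an amine placed elsewhere on the shared core would produce a clear effect in this assay at all.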